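Splenocyte cytotoxicity notes: hydroxymethyl to carboxy step

The source may hold more compounds than are shown below. What is called first, only, known or untested is meant among the compounds shown, and "the series" means these compounds.

Measured so far:
compound 1, `CCCCCCCCCCCCCCC(CO)NCCCC`, 16.4%
compound 2, `CCCCCCCCCCCCCCC(CO)N(CCCC)CCCC`, 11.7%

In an ADME assay on cells (Splenocyte, Mus musculus, strain BALB/c) for cytotoxicity, read by MTT assay, tested at 10 ug/mL (a higher number here means a stronger effect of the compound at the concentration tested, a lower number a weaker effect), compound 1 gives 16.4% and compound 2 gives 11.7%. The only measured step, a number 4.7 percentage points lower from compound 1 to compound 2 (within the scatter), comes from a butyl in place of hydrogen on an amine nitrogen, and it lies within the scatter; on the numbers shown compound 2 and compound 1 cannot be told apart in this assay.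

Compound 3, `CCCCCCCCCCCCCCC(C(=O)O)N(CCCC)CCCC`, is not yet measured. It differs from compound 2 by carboxy in place of hydroxymethyl on a saturated chain carbon bound to an amine nitrogen and a saturated chain carbon. For the measured compounds named here, no measured step touches this position or this kind of exchange: the step from compound 1 to compound 2 concerns the amine nitrogen only and says nothing about the hydroxymethyl carbon. There is therefore no basis in the series for expecting a step beyond the scatter in either direction, and the estimate for compound 3 is taken close to compound 2.

Compound 3 is expected to give 12% in this assay, with a range from 3% to 25%. The step this estimate implies is a number 0.3 percentage points higher from compound 2 to compound 3 (within the scatter), expected to stay within the scatter.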

Compound 3, a percentage reported as activity, at one concentration (the size of the read-out at that concentration, not a potency): 12.5%
Compound 3: the middle estimate sits 0.5 percentage points below what was measured, within the range that was stated.
By their numbers in this assay, from the lowest: compounds 2, 3 and 1 (each within the scatter of the next).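

In this assay, carboxy in place of hydroxymethyl on a saturated chain carbon bound to an amine nitrogen and a saturated chain carbon gives a number 0.8 percentage points higher from compound 2 to compound 3 (within the scatter), so this first exchange at that carbon does not separate the two compounds. The earlier step concerned the amine nitrogen only; the series now has one exchange at each of two places, and neither moves the read-out beyond the scatter. No measured property shown here bears on this result.

Open, as far as these compounds go, is whether a methyl ester, a primary amide or an aminomethyl group on the same carbon would also stay within the scatter of compound 2 at 11.7%, or whether one of them would produce a step beyond it. Also open, from the compounds shown here alone, is whether the carboxy exchange reads the same with a single butyl on the amine nitrogen, as in compound 1, and whether a shorter chain in place of the long saturated chain changes the picture at this carbon.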